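This account rests on a few compounds, and the source may have more. Where it says the series, first, only, none or still open, it means among the compounds named here.

Working notes on the series. Compound 1 `CN(C)CCn1cnnc1-c1cc(Oc2ccc(NC(=O)N/N=C/c3ccc(O)c(Br)c3)cc2F)ccn1` gives 12400 nM in a functional assay on U-87MG ATCC cells (Homo sapiens) for cytotoxicity, read by MTT assay, with a stated time of 72 h; on this read-out higher numbers stand for weaker inhibition and lower numbers for stronger inhibition. Compound 2 `CN(C)CCn1cnnc1-c1cc(Oc2ccc(NC(=O)N/N=C/c3ccccc3)cc2F)ccn1` gives 2250 nM in this assay, and compound 3 `CN(C)CCn1cnnc1-c1cc(Oc2ccc(NC(=O)N/N=C/c3cccc(Cl)c3Cl)cc2F)ccn1` gives 13200 nM in this assay. Within the data shown here, compound 3 holds the highest of the three numbers, though the step of a 1.1-fold higher number from compound 1 to compound 3 (0.03 log units; within the scatter) keeps compound 1 level with it, while the step of a 5.9-fold higher number from compound 2 to compound 3 (0.77 log units; beyond the scatter) and the step of a 5.5-fold lower number from compound 1 to compound 2 (0.74 log units; beyond the scatter) set compound 2 apart as the only number beyond the scatter from the other two.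

Compound 4 `Cc1cc(/C=N/NC(=O)Nc2ccc(Oc3ccnc(-c4nncn4CCN(C)C)c3)c(F)c2)cc(C)c1O` is not yet measured. 4-hydroxy-3,5-dimethylphenyl in place of 2,3-dichlorophenyl on a carbon with a double bond to nitrogen

Among the measured compounds shown here, two measured steps bear on this change, a 1.1-fold higher number from compound 1 to compound 3 (0.03 log units; within the scatter) and a 5.9-fold higher number from compound 2 to compound 3 (0.77 log units; beyond the scatter): a hydroxy-bearing aryl and the dichlorophenyl sit together, and only the plain phenyl of compound 2 gave a lower number. Compound 4 again carries a hydroxy-bearing aryl, so the step of a 1.3-fold lower number from compound 3 to compound 4 (0.12 log units; within the scatter) is expected to stay within the scatter, with a value for compound 4 estimated at 10000 nM, range 4000 nM to 25000 nM.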

Compound 4, half-maximal inhibitory concentration: 7710 nM
Beside the measured number, compound 4's estimate is 1.3-fold (0.11 log units) above it; the range from low to high includes it.
By their numbers in this assay, from the lowest: compound 2; then compounds 4, 1 and 3 (each within the scatter of the next).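

In this assay, the 4-hydroxy-3,5-dimethylphenyl group falls in with the other substituted rings at this position: a 1.7-fold lower number from compound 3 to compound 4 (0.23 log units; within the scatter) and a 1.6-fold lower number from compound 1 to compound 4 (0.21 log units; within the scatter) both stay within the scatter, while a 3.4-fold higher number from compound 2 to compound 4 (0.53 log units; beyond the scatter) lies beyond it. Compound 2, with its plain phenyl, now stands apart from three differently substituted rings on the carbon with a double bond to nitrogen, and that separation extends to a ring bearing methyl groups and a hydroxy as well as to the halogen-bearing rings of compound 1 and compound 3. Nothing available gives a reason for this separation.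

As far as these compounds go, whether a single methyl, a methoxy or an amine on the ring would stay with the substituted rings or come nearer compound 2 remains open. So does whether the gap persists with a longer chain on the shared core.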